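A few compounds are considered here, and "the series" means these few. Any claim that something is new, unique, unknown or untested is made for them only; others in the source may bear on it.

Measured so far:
compound 1 `N[C@H]1CC[C@H](NC(=O)c2nc(Br)c3cccnc3c2NCc2ccc(F)cc2)CC1` — 6600 nM
compound 2 `O=C(NCc1ccc(F)cc1)c1nc(Br)c2cccnc2c1NCCO` — > 20000 nM

In a functional assay on MDA-MB-435 cells (Homo sapiens) for cytotoxicity, read by MTT assay, with a stated time of 72 h (a lower number here means a stronger inhibitor, a higher number a weaker inhibitor), compound 1 gives 6600 nM. Compound 2 gives only a limit in this assay, > 20000 nM, so it sits at the limit of > 20000 nM in this assay, at which 1 of the 2 values shown sits, with no number of its own. Compound 3 `NCCCCCCNc1c(C(=O)NCc2ccc(F)cc2)nc(Br)c2cccnc12` differs from compound 2 by 4-aminobutyl in place of hydroxy on a saturated chain carbon, two bonds along the chain from a nitrogen on an aromatic ring: the hydroxy leaves and 4-aminobutyl enters on a saturated chain carbon, two bonds along the chain from a nitrogen on an aromatic ring. Among the measured compounds shown here, with compound 1 at 6600 nM as the only measured number, a step toward stronger inhibition is expected, of the size an at least 2.5-fold lower number from compound 2 to compound 3 (0.39 log units; beyond the scatter). Compound 3 is estimated at 8000 nM, between 3000 nM and 20000 nM.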

Compound 3, half-maximal inhibitory concentration: 6000 nM
Beside the measured number, compound 3's estimate is 1.3-fold (0.12 log units) above it; low and high end bracket the measured number.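

Exchanging (2-hydroxyethyl)amino for (6-aminohexyl)amino gives, in this assay, an at least 3.3-fold lower number from compound 2 to compound 3 (0.52 log units; beyond the scatter), so activity at this position responds to the group carried on the chain. The size of this step is open-ended because compound 2 has only a limit of the assay: the limit of > 20000 nM in this assay, at which 1 of the 3 values shown sits.

The change alters the amine and the chain length together, so the data do not show which one accounts for the step. A plain hexyl chain with no amine, or a shorter 3-aminopropyl chain, would separate the two.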